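The source may hold more compounds than are shown below. What is called first, only, known or untested is meant among the compounds shown, and "the series" means these compounds.

Measured so far in a physicochemical assay for solubility, in phosphate buffer, measured as kinetic solubility, with a stated time of 1 h, at pH 7.4; a higher number here means a more soluble compound, a lower number a less soluble compound:
- compound 1 `CCNC(=O)Nc1ccc(-c2nc(CS(C)(=O)=O)cc([C@]34CCOC[C@H]3C4)n2)cc1` gives 96 ug/mL
- compound 2 `CNCC(=O)Nc1ccc(-c2nc(CS(C)(=O)=O)cc([C@@]34CCOC[C@@H]3C4)n2)cc1` gives 167 ug/mL
- compound 3 `CCNC(=O)Nc1ccc(-c2nccc([C@@]34CCOC[C@@H]3C4)n2)cc1` gives 127 ug/mL

Compound 3 is second of these three numbers, but it lies within the usual scatter of both compound 1 and compound 2. On these data, its place in the row means little.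

The next compound is compound 4 `CCNC(=O)Nc1ccc(-c2nc(CS(C)(=O)=O)cc([C@@]34CCOC[C@@H]3C4)n2)cc1`. Here (methylsulfonyl)methyl takes the place of hydrogen on an aromatic carbon of a six-membered aromatic ring with 2 nitrogen ((methylsulfonyl)methyl in place of hydrogen on an aromatic carbon). Within the data shown here, no two measured compounds differ in that one place alone, so the size of this change has not been seen directly.

The nearest evidence is indirect. Compound 1 (96 ug/mL) and compound 2 (167 ug/mL) both carry (methylsulfonyl)methyl, and compound 3 (127 ug/mL) does not, yet all three values fall within the scatter of one another. A step in this assay beyond the scatter is therefore not expected, and no firm direction can be expected either. The estimated change is small (a 1.1-fold lower number from compound 3 to compound 4 (0.04 log units; within the scatter)).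

The estimate for compound 4 is 115 ug/mL (expected range 65 ug/mL to 200 ug/mL).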

Compound 4, solubility: 77 ug/mL
Compound 4: middle estimate off by 1.5-fold (0.17 log units), on the high side; the range from low to high includes it.
By their numbers in this assay, from the lowest: compounds 4, 1, 3 and 2 (each within the scatter of the next, the first and the last beyond it).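

In this assay, the effect of (methylsulfonyl)methyl in place of hydrogen on an aromatic carbon can now be read directly on one pair, a 1.6-fold lower number from compound 3 to compound 4 (0.22 log units; within the scatter), and this step lies within the scatter, so the pair gives no firm direction for the group at this position. Ethylamino in place of (methylamino)methyl on a carbonyl carbon gives the one step here that lies beyond the scatter, a 2.2-fold lower number from compound 2 to compound 4 (0.34 log units; beyond the scatter), though it is only modest in size. The mirror-image pair adds a third reading, a 1.2-fold lower number from compound 1 to compound 4 (0.10 log units; within the scatter), which also lies within the scatter, and the comparison is a clean one, with nothing else to separate the two: the fact that compounds 1 and 4 differ only in the configuration as drawn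

Going by these compounds, each of these changes rests on a single pair, so it remains open whether the same steps would appear with other groups elsewhere on the core. Also open, on these data alone, is how this assay would respond to a carboxylic acid in place of (methylsulfonyl)methyl on that aromatic carbon, or to a longer chain in place of ethylamino on the carbonyl carbon.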